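This account rests on a few compounds, and the source may have more. Where it says the series, first, only, none or still open, it means among the compounds named here.

Compound 1 `CC(C)c1ccc(Nc2nc(SCc3cn(CC(=O)NC(=O)Nc4ccccn4)nn3)nc(-c3ccc(C(C)C)cc3)c2C#N)cc1`: 2490 nM
Compound 2 `Cc1ccc(-c2nc(SCc3cn(CC(=O)NC(=O)Nc4ccccn4)nn3)nc(Nc3ccc(C(C)C)cc3)c2C#N)cc1`: 7450 nM

In a functional assay on ECa-109 cells (Homo sapiens) for inhibition, read by MTT assay, with a stated time of 72 h (on this read-out lower numbers stand for stronger inhibition and higher numbers for weaker inhibition), compound 2 gives 7450 nM, the highest of the two numbers, with compound 1 nearest at 2490 nM. Compound 3 `Cc1ccc(Nc2nc(SCc3cn(CC(=O)NC(=O)Nc4ccccn4)nn3)nc(-c3ccc(C)cc3)c2C#N)cc1` differs from compound 2 by methyl in place of isopropyl on an aromatic carbon, this time on the (4-isopropylphenyl)amino group, para to a large group. Among the measured compounds shown here, the one measured step that bears on it, a 3.0-fold higher number from compound 1 to compound 2 (0.48 log units; beyond the scatter), is the same exchange on the other aryl ring and moved the number beyond the scatter. Compound 3 is therefore expected to give 15000 nM, range 5000 nM to 45000 nM. That expectation means a step of a 2.0-fold higher number from compound 2 to compound 3 (0.30 log units; within the scatter).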

Compound 3, half-maximal inhibitory concentration: > 64000 nM
Compound 3 was reported as a limit; the forecaster's own chance of this, stated with the estimate: 10%; middle value at least 4.2-fold (0.63 log units) away from the limit.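

In this assay, exchanging isopropyl for methyl on the (4-isopropylphenyl)amino group gives an at least 8.5-fold higher number from compound 2 to compound 3 (0.93 log units; beyond the scatter), so this position also responds to the change, as the other aryl ring did with a 3.0-fold higher number from compound 1 to compound 2 (0.48 log units; beyond the scatter). Compound 3 is reported only as a limit, so the step has no upper bound: the limit of > 64000 nM in this assay, at which 1 of the 3 values shown sits.

The compounds shown leave open how methyl on this ring alone behaves while the other aryl ring keeps its isopropyl. They also leave open where an ethyl, a tert-butyl or an amine at this place would fall.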